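This account rests on a few compounds, and the source may have more. Where it says the series, first, only, none or still open, it means among the compounds named here.

Measured compounds in an assay on LtK cells with ATP-sensitive inward rectifier potassium channel 11 (Homo sapiens) as the target; on this read-out lower numbers stand for an effect already at smaller amounts and higher numbers for an effect only at larger amounts of compound:
Compound 1 `CCC(=O)Nc1c(C(O)(C(F)(F)F)C(F)(F)F)ccc2ccccc12` gives 15 nM.
Compound 2 `CC(C)=CC(=O)Nc1c(C(O)(C(F)(F)F)C(F)(F)F)ccc2ccccc12` gives 46 nM.
Compound 3 `CCCC(C)C(=O)Nc1c(C(O)(C(F)(F)F)C(F)(F)F)ccc2ccccc12` gives only a limit of the assay, > 10000 nM.

Among the two plain numbers, compound 1 has the lower one; the nearest is compound 2, reached by a 3.1-fold higher number from compound 1 to compound 2 (0.49 log units; beyond the scatter), a modest change that comes from putting 2-methylprop-1-en-1-yl in place of ethyl on the carbonyl carbon. The third value is a limit rather than a number, (the limit of > 10000 nM in this assay, at which 1 of the 3 values shown sits), and the step of an at least 660-fold higher number from compound 1 to compound 3 (2.82 log units; beyond the scatter) is large, coming from propyl in place of hydrogen on the saturated chain carbon bound to the carbonyl carbon.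

Compound 4 `O=C(Nc1c(C(O)(C(F)(F)F)C(F)(F)F)ccc2ccccc12)c1ccccc1Cl` has not yet been measured in this assay. Against compound 1 its change is 2-chlorophenyl in place of ethyl on a carbonyl carbon. Both measured steps that start from compound 1 alter the group carried by the carbonyl carbon, and both raise the number, one modestly and one at least up to the limit. The entering 2-chlorophenyl is larger than either of those groups, so a rise beyond the scatter is expected here too, most likely between the two measured steps in size. Compound 4 is therefore expected to give 300 nM, within a range from 50 nM to 3000 nM. The expected step from this estimate is a 20-fold higher number from compound 1 to compound 4 (1.30 log units; beyond the scatter).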

Compound 4, half-maximal effective concentration: 2040 nM
Compound 4: the middle estimate sits 6.8-fold (0.83 log units) below what was measured; the range from low to high includes it.
By their numbers in this assay, from the lowest: compound 1; then compound 2; then compound 4. At a limit, above all of these: compound 3.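

In this assay, going by these compounds alone, 2-chlorophenyl on the carbonyl carbon, the only group here that brings a ring, costs far more than the open-chain 2-methylprop-1-en-1-yl does: the result is a 140-fold higher number from compound 1 to compound 4 (2.13 log units; beyond the scatter), and measured from the 2-methylprop-1-en-1-yl compound it is a 44-fold higher number from compound 2 to compound 4 (1.65 log units; beyond the scatter). Yet the ring does not remove the effect altogether, since a plain number is still obtained, and replacing the branched 1-methylbutyl group with 2-chlorophenyl gives an at least 4.9-fold lower number from compound 3 to compound 4 (0.69 log units; beyond the scatter). Compound 3 contributes a limit and not a number, so this last step gives only a minimum size: the limit of > 10000 nM in this assay, at which 1 of the 4 values shown sits.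

With a single ring-bearing group, the compounds cannot separate the effect of the ring from that of its chlorine, and a plain phenyl on the carbonyl carbon would be the direct comparison. They also leave open how a pyridine ring, an amine or a carboxylic acid would read at this position, and whether a small ring such as cyclopropyl would stay nearer to the ethyl of compound 1.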